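The compounds below may be only part of what the source reports. "The series", "measured", "known", "first", "only" and "open" are said of these compounds alone.

Three compounds have been measured in a functional assay on A549 cells (Homo sapiens) for inhibition, read by MTT assay, with a stated time of 72 h (a lower number here means a stronger inhibitor, a higher number a weaker inhibitor), so far:

Compound 1 `C=CC(=O)Nc1cc(Nc2nc3c(c(-c4cn(C)c5ccc(F)cc45)n2)CS(=O)(=O)CC3)c(OC)cc1N(C)CCN(C)C` gives 4640 nM
Compound 2 `C=C(Cl)C(=O)Nc1cc(Nc2nc3c(c(-c4cn(C)c5ccc(F)cc45)n2)CS(=O)(=O)CC3)c(OC)cc1N(C)CCN(C)C` gives 3180 nM
Compound 3 `C/C=C\C(=O)Nc1cc(Nc2nc3c(c(-c4cn(C)c5ccc(F)cc45)n2)CS(=O)(=O)CC3)c(OC)cc1N(C)CCN(C)C` gives 3990 nM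

Compound 3, at 3990 nM, stands level with the other two, and its steps to both lie within the scatter. Compound 4 `CC/C=C\C(=O)Nc1cc(Nc2nc3c(c(-c4cn(C)c5ccc(F)cc45)n2)CS(=O)(=O)CC3)c(OC)cc1N(C)CCN(C)C` differs from compound 3 by methyl in place of hydrogen on a saturated chain carbon bound to a double-bonded chain carbon, with methyl in place of hydrogen on a saturated chain carbon bound to a double-bonded chain carbon, so prop-1-en-1-yl becomes but-1-en-1-yl. The closest guide is a 1.2-fold lower number from compound 1 to compound 3 (0.07 log units; within the scatter), where prop-1-en-1-yl replaced vinyl. The other two steps, a 1.5-fold lower number from compound 1 to compound 2 (0.16 log units; within the scatter) and a 1.3-fold higher number from compound 2 to compound 3 (0.10 log units; within the scatter), also stay within the scatter. No step beyond the scatter is therefore expected in this assay, the estimated step being a 1.0-fold higher number from compound 3 to compound 4 (0.00 log units; within the scatter). Compound 4 is estimated at 4000 nM, with an expected range from 2200 nM to 7300 nM.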

Compound 4, half-maximal inhibitory concentration: 5830 nM
For compound 4 the middle estimate is 1.5-fold (0.16 log units) below the measured one, within the range that was stated.
By their numbers in this assay, from the lowest: compounds 2, 3, 1 and 4 (each within the scatter of the next).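

In this assay, methyl in place of hydrogen on a saturated chain carbon bound to a double-bonded chain carbon, turning prop-1-en-1-yl into but-1-en-1-yl, gives a 1.5-fold higher number from compound 3 to compound 4 (0.16 log units; within the scatter). The other new steps, a 1.8-fold higher number from compound 2 to compound 4 (0.26 log units; within the scatter) and a 1.3-fold higher number from compound 1 to compound 4 (0.10 log units; within the scatter), also stay within the scatter, so vinyl, 1-chloroethenyl, prop-1-en-1-yl and but-1-en-1-yl on the carbonyl carbon remain level. No measurement shown bears on the reason for these numbers. Going by these compounds, whether a longer chain or a dimethylamino group on the but-1-en-1-yl chain would give a step beyond the scatter remains open.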